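Cyclohexyl in place of 4-(trifluoromethyl)phenyl: working notes

This account rests on a few compounds, and the source may have more. Where it says the series, first, only, none or still open, it means among the compounds named here.

Compound 1 `O=C1C(NC2CCCC2)=CC(=O)c2c1nc1n2[C@H]2OC[C@@H](O)[C@H]2OC1` gives > 16000 nM (a limit)
Compound 2 `COc1ccccc1NC1=CC(=O)c2c(nc3n2[C@H]2OC[C@@H](O)[C@H]2OC3)C1=O` gives > 4000 nM (a limit)
Compound 3 `O=C1C(Nc2ccc(C(F)(F)F)cc2)=CC(=O)c2c1nc1n2[C@H]2OC[C@@H](O)[C@H]2OC1` gives 2250 nM (a number)

All values come from a functional assay on ECa-109 cells for inhibition, with ECa-109 cell line (Homo sapiens) as the target, read by sulforhodamine B assay (on this read-out lower numbers stand for stronger inhibition and higher numbers for weaker inhibition), and only compound 3 has a number; the other two values are limits. The change to compound 4 `O=C1C(NC2CCCCC2)=CC(=O)c2c1nc1n2[C@H]2OC[C@@H](O)[C@H]2OC1` is cyclohexyl in place of 4-(trifluoromethyl)phenyl on an amine nitrogen on the shared core. The nearest measured change runs the opposite way: 4-(trifluoromethyl)phenyl in place of cyclopentyl gave an at least 7.1-fold lower number from compound 1 to compound 3 (0.85 log units; beyond the scatter) in this series. The steps of an at least 1.7-fold lower number from compound 2 to compound 3 (0.24 log units; that floor lies within the scatter) and a step that the two limits leave unreadable from compound 1 to compound 2 say less. Compound 1, whose cyclopentyl is closest to cyclohexyl, gave the limit > 16000 nM as its reading. Weaker inhibition of similar size is therefore expected, with a 6.2-fold higher number from compound 3 to compound 4 (0.79 log units; beyond the scatter) as the estimated step. Compound 4 is estimated at 14000 nM (range 5000 nM to 40000 nM) and may return only a limit.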

Compound 4, half-maximal inhibitory concentration: > 16000 nM
Compound 4: no number, only a limit; the forecaster's own chance of this, stated with the estimate: 55%; middle value at least 1.1-fold (0.05 log units) from the limit.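

In this assay, the change to cyclohexyl gives an at least 7.1-fold higher number from compound 3 to compound 4 (0.85 log units; beyond the scatter), so both non-aromatic carbon rings shown on this amine nitrogen, cyclopentyl and cyclohexyl, now have a step beyond the scatter from 4-(trifluoromethyl)phenyl. Compound 4 gives > 16000 nM, which is a limit. The steps to compound 4 from compound 1 and compound 2 cannot be read because limits stand at both ends: the limit of > 16000 nM in this assay, at which 2 of the 4 values shown sit.

Still open, as far as these compounds go, is whether the step belongs to the aromatic ring itself or to its trifluoromethyl. Unsubstituted phenyl or 4-chlorophenyl on the same amine nitrogen would separate the two.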